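This account rests on a few compounds, and the source may have more. Where it says the series, first, only, none or still open, it means among the compounds named here.

Three compounds share one core and differ only in the acyl group on the amide nitrogen. Compound 1, `CC(=O)Nc1cc(Oc2ccc(Nc3nccc4[nH]cc(-c5ccc(F)cc5)c(=O)c34)cc2F)ccn1`, carries an acetyl group and gives 36.8% in a functional assay on HT-29 cells (Homo sapiens) for antiproliferative activity, read by MTT assay, with a stated time of 72 h, tested at 10 uM; a higher number here means more inhibition at the concentration tested (going by the name of the read-out), a lower number less inhibition. Compound 2, `CC(C)C(=O)Nc1cc(Oc2ccc(Nc3nccc4[nH]cc(-c5ccc(F)cc5)c(=O)c34)cc2F)ccn1`, carries an isopropyl group on the carbonyl carbon and gives 83.4% in this assay. Compound 3, `CCC(=O)Nc1cc(Oc2ccc(Nc3nccc4[nH]cc(-c5ccc(F)cc5)c(=O)c34)cc2F)ccn1`, carries a propanoyl group and gives 68.7% in this assay, which places it second highest of the three numbers, with the step of a number 14.7 percentage points lower from compound 2 to compound 3 (beyond the scatter) and the step of a number 31.9 percentage points higher from compound 1 to compound 3 (beyond the scatter).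

Compound 4, `CCCCC(=O)Nc1cc(Oc2ccc(Nc3nccc4[nH]cc(-c5ccc(F)cc5)c(=O)c34)cc2F)ccn1`, is not yet measured. It differs from compound 3 by ethyl in place of hydrogen on a saturated chain carbon, two bonds along the chain from a carbonyl carbon. Going by the values given here, the steps that bear on this change are those that enlarge the acyl group: a number 31.9 percentage points higher from compound 1 to compound 3 (beyond the scatter) and a number 46.6 percentage points higher from compound 1 to compound 2 (beyond the scatter), both large and both toward more inhibition. Lengthening the chain further is therefore expected to raise the number again, though the only comparison for a longer straight chain so far is from compound 1 to compound 3, so the size is uncertain. For compound 4 the expected step is a number 11.3 percentage points higher from compound 3 to compound 4 (beyond the scatter), and the estimated value for compound 4 is 80%, within a range from 60% to 95%.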

Compound 4, a percentage reported as inhibition, at one concentration (the size of the read-out at that concentration, not a potency): -42.2%
Beside the measured number, compound 4's estimate is 122.2 percentage points above it, and the stated range ends above it.
By their numbers in this assay, from the lowest: compound 4; then compound 1; then compound 3; then compound 2.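

In this assay, going by these compounds alone, the rise seen as the acyl group grew from compound 1 to compound 3 does not continue at this position: adding ethyl to the chain carbon gives a number 110.9 percentage points lower from compound 3 to compound 4 (beyond the scatter) and turns the read-out negative, with compound 4 at -42.2% as the only negative number of the four. Size alone therefore does not set the trend in this small set, as butyl in place of isopropyl on the carbonyl carbon gives a number 125.6 percentage points lower from compound 2 to compound 4 (beyond the scatter) and the full change from the acetyl compound gives a number 79 percentage points lower from compound 1 to compound 4 (beyond the scatter) and ends below where the series began. Nothing available here accounts for this reversal.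

As far as these compounds go, whether the fall continues with a longer chain, such as pentyl on the carbonyl carbon, stays open. So does whether a branched group such as tert-butyl or a ring such as cyclopropyl in that place would follow isopropyl or butyl.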